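Methyl for methoxy on the aryl ring of compound 3

The source may report more compounds than this note shows. Statements on the series, on what has been measured and on what is new or still open speak of the compounds shown alone.

Compound 3 `COc1ccc(-c2nc3sc(Cc4ccc(Cl)cc4)nn3c2SC#N)cc1` holds the lowest of the two numbers obtained in a functional assay on L1210 cells (Mus musculus) for cytotoxicity, with a stated time of 48 h (a higher number here means a weaker inhibitor, a lower number a stronger inhibitor), where compound 3 gives 16000 nM. Within the data shown here, compound 2 `N#CSc1c(-c2ccc(Cl)cc2)nc2sc(Cc3ccc(Cl)cc3)nn12` gives 49000 nM in this assay, and the step of a 3.1-fold lower number from compound 2 to compound 3 (0.49 log units; beyond the scatter) is the only measured change on that ring. Compound 1 `Cc1ccc(-c2nc3sc(Cc4ccc(Cl)cc4)nn3c2Br)cc1` reaches only the limit of this assay, giving > 250000 nM; it shares the methyl group with compound 4 but not the thiocyanate, so its result is noted without a step (the limit of > 250000 nM in this assay, at which 1 of the 3 values shown sits). Compound 4 `Cc1ccc(-c2nc3sc(Cc4ccc(Cl)cc4)nn3c2SC#N)cc1` differs from compound 3 by methyl in place of methoxy on an aromatic carbon. Among the measured compounds shown here, no measured step covers methyl against methoxy directly; the one measured step on this ring was modest, so a modest step in this assay is expected here, most likely towards a higher number, with the estimated step of a 1.9-fold higher number from compound 3 to compound 4 (0.27 log units; within the scatter). Compound 4 is therefore expected to give about 30000 nM in this assay, within a range from 10000 nM to 100000 nM.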

Compound 4, half-maximal inhibitory concentration: 32000 nM
The estimate for compound 4 lay 1.1-fold (0.03 log units) below the measured number; low and high end bracket the measured number.
By their numbers in this assay, from the lowest: compounds 3, 4 and 2 (each within the scatter of the next, the first and the last beyond it). At a limit, above all of these: compound 1.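

In this assay, methyl in place of methoxy gives a 2.0-fold higher number from compound 3 to compound 4 (0.30 log units; within the scatter), so the change from 4-methoxyphenyl to 4-methylphenyl cannot be told apart from repeat measurement. The step of a 1.5-fold lower number from compound 2 to compound 4 (0.19 log units; within the scatter) likewise leaves methyl and chloro unseparated at this position, and only the methoxy and chloro pair of compounds, at the two ends of the series, lies beyond the scatter. Cyanosulfanyl in place of bromo gives the largest step in the series, an at least 7.8-fold lower number from compound 1 to compound 4 (0.89 log units; beyond the scatter), and that step rests on a limit, not a number: the limit of > 250000 nM in this assay, at which 1 of the 4 values shown sits.

As far as these compounds go, it remains open whether an amine or a carboxylic acid on the aromatic ring would move the number further than these three groups do. The compounds shown also leave open whether a longer chain in place of methyl would change the number at all.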